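Cytotoxicity Expected Unchanged for Thiazolylmethyl Ether Analogue

A few compounds are considered here, and "the series" means these few. Any claim that something is new, unique, unknown or untested is made for them only; others in the source may bear on it.

Compound 1 `O=c1[nH]cc(-c2cc(-c3cc(Cl)cc(OCc4scnc4C(F)(F)F)c3)c(=O)n(-c3cccnc3)c2)c(=O)[nH]1` was tested in an ADME assay on 16HBE14o- cells (Homo sapiens) for cytotoxicity, read by MTT assay, with a stated time of 72 h (on this read-out lower numbers stand for higher toxicity in this test and higher numbers for lower toxicity in this test), and reached only the assay limit of > 100000 nM. Compound 2 `Cn1cc(-c2cc(-c3cc(Cl)cc(OCC4CC4)c3)c(=O)n(-c3cccnc3)c2)c(=O)[nH]c1=O` likewise gave only the limit of > 100000 nM in this assay. Going by the values given here, compound 3 `Cn1cc(-c2cc(-c3cc(Cl)cc(OCCC(F)(F)F)c3)c(=O)n(-c3cccnc3)c2)c(=O)[nH]c1=O` is the one member of the set that gave a number in this assay, 95000 nM. Among the compounds with values here, the single measured step, an at least 1.0-fold lower number from compound 2 to compound 3 (0.02 log units; that floor lies within the scatter), is within the scatter, and the limit of > 100000 nM in this assay, at which 2 of the 3 values shown sit, shows that the set as a whole sits at or near the top of the measurable window.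

Compound 4 `Cn1cc(-c2cc(-c3cc(Cl)cc(OCc4scnc4C(F)(F)F)c3)c(=O)n(-c3cccnc3)c2)c(=O)[nH]c1=O` differs from compound 3 by a group of 9 heavy atoms (4 carbon, 1 nitrogen, 3 fluorine, 1 sulfur; one five-membered aromatic ring with 2 hetero atoms) in place of a group of 5 heavy atoms (2 carbon, 3 fluorine; no ring), on a saturated chain carbon bound to an oxygen on an aromatic ring. Within the data shown here, only the step from compound 2 to compound 3 bears on this change, and it showed nothing beyond the scatter, so no step beyond the scatter is expected in this assay in either direction. The estimated step of a 1.1-fold higher number from compound 3 to compound 4 (0.02 log units; within the scatter) is therefore close to flat for compound 4. Compound 4 is expected to give about 100000 nM in this assay, between 50000 nM and 200000 nM, with a good chance that only a limit is reported.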

Compound 4, half-maximal cytotoxic concentration: > 100000 nM
Compound 4 ended at the assay's limit; the forecaster's own chance of this, stated with the estimate: 65%; the middle value sits exactly at the limit.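

In this assay, the group with a five-membered aromatic ring and 2 hetero atoms in place of 2,2,2-trifluoroethyl, on a saturated chain carbon bound to an oxygen on an aromatic ring, gave an at least 1.0-fold higher number from compound 3 to compound 4 (0.02 log units; that floor lies within the scatter), so this place has now taken a ring-bearing group with 2 hydrogen-bond acceptors without a step beyond the scatter. The steps to compound 4 from compound 2 and from compound 1 cannot be read, as both ends of each are limits, so the methyl in place of hydrogen on an aromatic nitrogen shows no readable effect here. The set now stands still more firmly at the top of the window: the limit of > 100000 nM in this assay, at which 3 of the 4 values shown sit.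

As far as these compounds go, whether an amine or a carboxylic acid at this place would bring the number in this assay down beyond the scatter stays open. So does the outcome of an ethyl group in place of the methyl on the aromatic nitrogen.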